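The source may report more compounds than this note shows. Statements on the series, on what has been measured and on what is new or still open speak of the compounds shown alone.

Measured compounds:
compound 1 `Cn1cccc1-c1ccccc1NCC1=NCCN1`, 103% in a functional assay with Alpha-1A adrenergic receptor (Homo sapiens) as the target, read by calcium flux; a higher number here means a larger maximal response, a lower number a smaller maximal response
compound 2 `c1ccc(-c2cn[nH]c2)c(NCC2=NCCN2)c1`, 112%
compound 3 `c1ccc(-c2nc[nH]n2)c(NCC2=NCCN2)c1`, 135%

Compound 3 stands highest of the three; its nearest neighbour is compound 2, with a number 23 percentage points higher from compound 2 to compound 3 (beyond the scatter), and the furthest is compound 1, with a number 32 percentage points higher from compound 1 to compound 3 (beyond the scatter). Compound 4 `Cn1ccnc1-c1ccccc1NCC1=NCCN1` differs from compound 3 in one place: 1-methyl-1H-imidazol-2-yl in place of 1H-1,2,4-triazol-3-yl on an aromatic carbon. The entering group resembles that of compound 1 in carrying a methyl and no hydrogen-bond donor, so the step from compound 1 to compound 3 bears on it most, together with the smaller step from compound 2 to compound 3. Because a number 32 percentage points higher from compound 1 to compound 3 (beyond the scatter), a reversal of that direction is expected, giving a modest decrease of a number 27 percentage points lower from compound 3 to compound 4 (beyond the scatter). Compound 4 is therefore estimated at 108%, between 90% and 128%.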

Compound 4, largest response reached (reported as maximal response), in percent of the reference or control that the assay uses: 88%
Compound 4: the middle estimate sits 20 percentage points above what was measured; the measured number lies below the stated range.
By their numbers in this assay, from the lowest: compound 4; then compounds 1 and 2 (each within the scatter of the next); then compound 3.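

At this position, the 1-methyl-1H-imidazol-2-yl group gives the lowest response of the set, with a number 47 percentage points lower from compound 3 to compound 4 (beyond the scatter) and a number 24 percentage points lower from compound 2 to compound 4 (beyond the scatter). Two groups that each carry a methyl and no hydrogen-bond donor are also not interchangeable here, as a number 15 percentage points lower from compound 1 to compound 4 (beyond the scatter) shows, and compound 1 goes against any simple link between a donor and a higher response. Nothing measured explains these differences. Still open, on these data alone, is whether 1H-imidazol-2-yl, without the methyl, would fall nearer compound 3 or compound 4. As far as these compounds go, how a plain phenyl or a 1-ethyl-1H-imidazol-2-yl group would behave at this position also remains open.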